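This account rests on a few compounds, and the source may have more. Where it says the series, first, only, none or still open, it means among the compounds named here.

Compound 1 `Nc1cc(N)c2nc(-c3ccccc3)c(NCc3ccc(Cl)c(Cl)c3)nc2c1` and compound 2 `COc1ccc(CNc2nc3cc(N)cc(N)c3nc2-c2ccccc2)cc1OC` share one core and differ only in the group on the saturated chain carbon bound to a nitrogen on an aromatic ring. In a functional assay on OVCAR-3 cells (Homo sapiens) for inhibition, read by sulforhodamine B assay, with a stated time of 48 h (on this read-out higher numbers stand for weaker inhibition of growth and lower numbers for stronger inhibition of growth), compound 1 gives 2630 nM, and in this assay compound 2 gives 1320 nM. For the measured compounds named here, the only measured step, a 2.0-fold lower number from compound 1 to compound 2 (0.30 log units; within the scatter), does not separate the two compounds, so compound 2 cannot be ranked against compound 1 on these numbers. Compound 3 `COc1cc(CNc2nc3cc(N)cc(N)c3nc2-c2ccccc2)cc(OC)c1OC` is reached from compound 2 by methoxy in place of hydrogen on an aromatic carbon. Going by the values given here, the one measured step bears on this change only loosely: replacing the whole substituent pattern on that ring left the number in this assay within the scatter, and here only a single methoxy is added. The estimate for compound 3 is therefore a step of a 1.0-fold lower number from compound 2 to compound 3 (0.01 log units; within the scatter), with no direction expected beyond the scatter. Compound 3 is expected to give 1300 nM in this assay, with a range from 500 nM to 3500 nM.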

Compound 3, concentration for 50% growth inhibition: 1150 nM
Compound 3: the middle estimate sits 1.1-fold (0.05 log units) above what was measured, within the range that was stated.
By their numbers in this assay, from the lowest: compounds 3, 2 and 1 (each within the scatter of the next, the first and the last beyond it).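

Methoxy in place of hydrogen on this aromatic carbon, ortho to a methoxy group and meta to a large group, gives a 1.1-fold lower number from compound 2 to compound 3 (0.06 log units; within the scatter) in this assay. Where the earlier step exchanged the whole substituent pattern on the ring, this step isolates one added group at one position, and compound 3 cannot be told apart from compound 2 on these numbers. Nothing at hand accounts for this result.

The compounds shown leave open whether a different group on this aromatic carbon, such as an amine or a carboxylic acid, would give a step beyond the scatter. They also leave open whether a longer chain between the ring and the nitrogen would do so.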